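This account rests on a few compounds, and the source may have more. Where it says the series, first, only, none or still open, it means among the compounds named here.

Compound 1: `CCC(C)(C)Cc1c[nH]c(CCc2ccc(-c3cccc(C)n3)cc2)n1` — 19 nM
Compound 2: `CCC(C)(C)Cc1c[nH]c(CCc2ccc(-n3cccn3)cc2)n1` — 9 nM
Compound 3: `CCC(C)(C)Cc1c[nH]c(CCc2ccc(-n3ncnn3)cc2)n1` — 25 nM

In a functional assay on HEK293 cells for agonist activity at Bombesin receptor subtype-3 (Mus musculus), read by luminescence and calcium flux, with a stated time of 10 min (a lower number here means that less compound is needed, a higher number that more compound is needed for the effect), compound 3 gives the highest of the three numbers; its gap to compound 1 lies within the scatter, while a 2.8-fold higher number from compound 2 to compound 3 (0.44 log units; beyond the scatter) is a modest step. Compound 4, `CCC(C)(C)Cc1c[nH]c(CCc2ccc(-c3cnccn3)cc2)n1`, carries pyrazin-2-yl in place of 2H-tetrazol-2-yl on an aromatic carbon. The step that bears most directly on this change runs the other way round on a related pair: a 1.3-fold higher number from compound 1 to compound 3 (0.12 log units; within the scatter), a six-membered heteroaryl attached through carbon against the tetrazolyl, stayed within the scatter. Among the measured compounds shown here, the only step that went beyond it, a 2.8-fold higher number from compound 2 to compound 3 (0.44 log units; beyond the scatter), concerned a different five-membered ring. Compound 4 is therefore expected to return roughly to where compound 1 sits, and a 1.4-fold lower number from compound 3 to compound 4 (0.14 log units; within the scatter) is estimated to be small. Compound 4 is expected to give 18 nM, with a range from 7 nM to 45 nM in this assay.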

Compound 4, half-maximal effective concentration: 11 nM
Compound 4: middle estimate off by 1.6-fold (0.21 log units), on the high side; low and high end bracket the measured number.
By their numbers in this assay, from the lowest: compounds 2, 4, 1 and 3 (each within the scatter of the next, the first and the last beyond it).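

In this assay, pyrazin-2-yl in place of 2H-tetrazol-2-yl is a step beyond the scatter (a 2.3-fold lower number from compound 3 to compound 4 (0.36 log units; beyond the scatter)), so this is the second group on this aromatic carbon, after 1H-pyrazol-1-yl, to separate from the tetrazolyl. Pyrazin-2-yl itself stays within the scatter of the other two rings (a 1.2-fold higher number from compound 2 to compound 4 (0.09 log units; within the scatter) and a 1.7-fold lower number from compound 1 to compound 4 (0.24 log units; within the scatter)), so a six-membered ring with two ring nitrogens fits here as well as the pyrazolyl does. No measurement shown accounts for these differences. The compounds shown carry only aromatic rings at this place, so what a carboxylic acid, an amine or a longer chain would give here stays open.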